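Removing one methoxy group from a trimethoxyphenyl pyrazole enone

The source may hold more compounds than are shown below. What is called first, only, known or untested is meant among the compounds shown, and "the series" means these compounds.

Three compounds were measured in a functional assay on OVCAR-3 cells (Homo sapiens) for cytotoxicity, read by sulforhodamine B assay, with a stated time of 48 h, tested at 100 uM; on this read-out lower numbers stand for a stronger effect and higher numbers for a weaker effect at the one concentration tested:
- compound 1 `COc1ccc(-c2cc(/C=C/C(=O)c3ccc(N)cc3)[nH]n2)cc1`, giving -85%
- compound 2 `COc1cc(-c2cc(/C=C/C(=O)c3ccc(N)cc3)[nH]n2)cc(OC)c1OC`, giving -93%
- compound 3 `COc1cc(-c2cc(/C=C/C(=O)c3ccc(Cl)c(Cl)c3)[nH]n2)cc(OC)c1OC`, giving -30%

Compound 2 has the lowest number of the three in this assay. Its nearest neighbour is compound 1, whose value lies within the scatter of that of compound 2, so no order between these two can be claimed. The furthest is compound 3, reached by the step of a number 63 percentage points higher from compound 2 to compound 3 (beyond the scatter), a change at the carbonyl side of the molecule.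

Compound 4 `COc1ccc(-c2cc(/C=C/C(=O)c3ccc(N)cc3)[nH]n2)cc1OC` differs from compound 2 only on the aromatic ring away from the carbonyl: hydrogen in place of methoxy on an aromatic carbon. Among the compounds with values here, the one measured step, from compound 2 to compound 3, concerns the other end of the molecule and therefore does not bear directly on this change. Within the data shown here, the only guidance is that compound 1, with a single methoxy group on that ring, and compound 2, with three, give values within the scatter of each other. On that basis the step of a number 5 percentage points higher from compound 2 to compound 4 (within the scatter) is expected to stay within the scatter. Compound 4 is therefore estimated at -88% in this assay, with a range from -100% to -70%.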

Compound 4, a percentage reported as activity, at one concentration (the size of the read-out at that concentration, not a potency): -99%
Estimate against measurement, compound 4: 11 percentage points above; measured number inside the range.
By their numbers in this assay, from the lowest: compounds 4, 2 and 1 (each within the scatter of the next, the first and the last beyond it); then compound 3.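

In this assay the change of hydrogen in place of methoxy on this aromatic carbon gives a number 6 percentage points lower from compound 2 to compound 4 (within the scatter), so the trimethoxyphenyl compound and its analogue with one methoxy group fewer cannot be told apart, and this methoxy group is not needed for the effect seen at the one concentration tested. Within the data shown here, the methoxy group that compound 4 keeps and compound 1 lacks does register, with methoxy in place of hydrogen on an aromatic carbon giving a number 14 percentage points lower from compound 1 to compound 4 (beyond the scatter), a modest step that the earlier compounds could not show. Nothing given here accounts for either step.

Going by these compounds, all of these steps on the methoxy-bearing ring were read with 4-aminophenyl on the carbonyl, so it remains open whether the same removal would be as small a change with the 3,4-dichlorophenyl group of compound 3. Also open, on these data alone, is what a hydroxy group, an ethoxy group or a fluorine atom would give on this aromatic carbon in place of the methoxy group or the hydrogen.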